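Bis(aryl)methylpiperazine Amides: Anticipating Compound 4 in Cytotoxicity

This account rests on a few compounds, and the source may have more. Where it says the series, first, only, none or still open, it means among the compounds named here.

Of the compounds shown here, three sharing a piperazine amide core have been measured. Compound 1 `COc1ccc(C(c2ccc(OC)cc2)N2CCN(C(=O)COc3ccc4ccccc4c3)CC2)cc1` gives 2.55% in a functional assay on PC-12 cells (Rattus norvegicus) for cytotoxicity, read by MTT assay, with a stated time of 24 h, tested at 0.1 uM; a lower number here means a weaker effect, a higher number a stronger effect of the compound at the concentration tested. Compound 2 `O=C(COc1ccc2ccccc2c1)N1CCN(C(c2ccc(Br)cc2)c2ccc(Br)cc2)CC1` gives 4.06% in this assay, a number within the scatter of compound 1. Compound 3 `COc1ccc(OCC(=O)N2CCN(C(c3ccc(OC)cc3)c3ccc(OC)cc3)CC2)cc1` gives 59.4%, the highest of the three. The difference between the cores of compound 1 and compound 2 is not broken down here.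

The measured step 4-methoxyphenyl in place of naphthalen-2-yl on an oxygen on a saturated carbon made a number 56.9 percentage points higher from compound 1 to compound 3 (beyond the scatter), the one large effect seen in this set.

Compound 4 `COc1ccc(OCC(=O)N2CCN(C(c3ccc(Br)cc3)c3ccc(Br)cc3)CC2)cc1` is not yet measured. It differs from compound 2 by 4-methoxyphenyl in place of naphthalen-2-yl on an oxygen on a saturated carbon, the same change that separates compound 1 from compound 3.

Because compound 1 rose by a number 56.9 percentage points higher from compound 1 to compound 3 (beyond the scatter), compound 4 is expected to move from compound 2 by an estimated a number 45.9 percentage points higher from compound 2 to compound 4 (beyond the scatter) in this assay. This rests on a single measured example of the change, so the expectation carries wide uncertainty. Compound 4 is therefore estimated at 50%, likely between 15% and 75%.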

Compound 4, a percentage reported as activity, at one concentration (the size of the read-out at that concentration, not a potency): 3.52%
Compound 4: middle estimate off by 46.5 percentage points, on the high side, and the stated range ends above it.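

In this assay, 4-methoxyphenyl in place of naphthalen-2-yl on an oxygen on a saturated carbon gave, on the core carrying bromine, a number 0.5 percentage points lower from compound 2 to compound 4 (within the scatter). For the compounds shown here, the large rise seen on the core carrying methoxy groups therefore did not carry over, and the effect of the change depends on the core it is made on: the same change on two cores in this assay, a number 56.9 percentage points higher (beyond the scatter) from compound 1 to compound 3 and a number 0.5 percentage points lower (within the scatter) from compound 2 to compound 4, 57.4 percentage points apart, beyond the scatter of two such steps This shows only that the step cannot be moved from one core to the other here; with one pair on each core, it does not show which feature of the cores sets the two steps apart, nor how the change would behave on any third core.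

The compounds shown leave open whether the rise would return with fluorine or a trifluoromethyl group on the two aryl rings in place of bromine. They also leave open whether a phenoxy group without methoxy, or a longer chain between the oxygen and the carbonyl, would keep the rise on the core carrying methoxy groups.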